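The source may report more compounds than this note shows. Statements on the series, on what has been measured and on what is new or still open speak of the compounds shown alone.

Working notes on the oxazolidinone amide series.

Compound 2 `Cc1ccc(CCCCCC(=O)N2CCOC2=O)cc1` and compound 1 `O=C(CCCCCc1ccc(Cl)cc1)N1CCOC1=O` share one core and differ in a single place: chloro in place of methyl on an aromatic carbon. In an assay on HEK293 cells for inhibition of N-acylethanolamine-hydrolyzing acid amidase (Rattus norvegicus), read by LC-MS, with a stated time of 30 min (on this read-out lower numbers stand for stronger inhibition and higher numbers for weaker inhibition), compound 2 gives 440 nM, and in the same run compound 1 gives 4600 nM; the step is a 10-fold higher number from compound 2 to compound 1 (1.02 log units; beyond the scatter).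

Compound 3 `Cc1ccccc1CCCCCC(=O)N1CCOC1=O` is built from the same atoms as compound 2, joined differently; the difference between the two cores is not broken down here. In this assay compound 3 gives only a limit, > 20000 nM.

Compound 4 `O=C(CCCCCc1ccccc1Cl)N1CCOC1=O` is not yet measured. From compound 3 to compound 4 the change is chloro in place of methyl on an aromatic carbon. This is the same kind of change as from compound 2 to compound 1, not the same: there the chloro sits para to a large group, here it sits ortho to a large group. Among the measured compounds shown here, the one measured instance of the change, a 10-fold higher number from compound 2 to compound 1 (1.02 log units; beyond the scatter), moved the read-out toward weaker inhibition, and compound 3 already stands at a limit. On that basis the step from compound 3 to compound 4 in this assay is expected to be a step that the limit leaves unreadable from compound 3 to compound 4, at or beyond the range of the measurement. The estimate for compound 4 is 40000 nM, with a band from 15000 nM to 150000 nM. A limit rather than a number is the likely report for compound 4 because the limit of > 20000 nM in this assay, at which 1 of the 3 values shown sits, is already where compound 3 sits.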

Compound 4, half-maximal inhibitory concentration: > 20000 nM
Compound 4 gave a limit, no number; the forecaster's own chance of this, stated with the estimate: 85%; the middle value is on the limit's open side.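

No step can be read between compound 3 and compound 4 in this assay, where both results are limits and not numbers: the limit of > 20000 nM in this assay, at which 2 of the 4 values shown sit.

The compounds shown leave open how far chloro in place of methyl, ortho to a large group, moves the read-out, and whether that change matches the one seen at the other place, a 10-fold higher number from compound 2 to compound 1 (1.02 log units; beyond the scatter).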